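The compounds below may be only part of what the source reports. "The series", "measured", "known", "first", "only" and "open" are said of these compounds alone.

Four compounds share one core and differ in a single group on an aromatic carbon. In a toxicity assay on MT4 cells (Homo sapiens) for cytotoxicity, read by MTT assay, with a stated time of 5 days (on this read-out higher numbers stand for lower toxicity in this test and lower numbers for higher toxicity in this test), compound 1 (`Cc1cc(-c2ccco2)cc(C)c1Nc1ccnc(Nc2ccc(C#N)cc2)n1`) gives 1700 nM, compound 2 (`Cc1cc(-c2ccnc3ccccc23)cc(C)c1Nc1ccnc(Nc2ccc(C#N)cc2)n1`) gives 3500 nM and compound 3 (`Cc1cc(-c2cc(C)c(Nc3ccnc(Nc4ccc(C#N)cc4)n3)c(C)c2)ccn1`) gives 4900 nM. Compound 3 therefore shares the top of this small set with one other compound, as the data show a 1.4-fold higher number from compound 2 to compound 3 (0.15 log units; within the scatter). The lower end stands apart, with a 2.1-fold higher number from compound 1 to compound 2 (0.31 log units; beyond the scatter) and a 2.9-fold higher number from compound 1 to compound 3 (0.46 log units; beyond the scatter).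

Compound 4 (`Cc1ncc(-c2cc(C)c(Nc3ccnc(Nc4ccc(C#N)cc4)n3)c(C)c2)cn1`) carries 2-methylpyrimidin-5-yl in place of 2-methylpyridin-4-yl on an aromatic carbon, meta to two methyl groups and para to a large group: 2-methylpyrimidin-5-yl in place of 2-methylpyridin-4-yl on an aromatic carbon. Among the compounds with values here, no measured step makes this exact exchange. The closest one swaps one nitrogen-containing aromatic group for another, and it stayed within the scatter: a 1.4-fold higher number from compound 2 to compound 3 (0.15 log units; within the scatter). The two steps away from furan-2-yl were modest, and they replace a different kind of group. A step beyond the scatter is therefore not expected in this assay, in either direction. The estimated step is a 1.2-fold lower number from compound 3 to compound 4 (0.09 log units; within the scatter), and it is expected to remain within the scatter. For compound 4 the expected value is 4000 nM, with an estimated range from 1500 nM to 11000 nM.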

Compound 4, half-maximal cytotoxic concentration: 3900 nM
Compound 4: the middle estimate sits 1.0-fold (0.01 log units) above what was measured; low and high end bracket the measured number.
By their numbers in this assay, from the lowest: compound 1; then compounds 2, 4 and 3 (each within the scatter of the next).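

In this assay, the exchange of 2-methylpyridin-4-yl for 2-methylpyrimidin-5-yl, which brings a second ring nitrogen and a second hydrogen-bond acceptor, gives a 1.3-fold lower number from compound 3 to compound 4 (0.10 log units; within the scatter), and the exchange of quinolin-4-yl for the same group gives a 1.1-fold higher number from compound 2 to compound 4 (0.05 log units; within the scatter), so compound 2, compound 3 and compound 4 cannot be told apart on this read-out. Furan-2-yl still stands alone at this place, meta to two methyl groups and para to a large group, with a 2.3-fold higher number from compound 1 to compound 4 (0.36 log units; beyond the scatter), and all three nitrogen-containing groups now lie beyond the scatter from it, with no listed compound going against this. No measured information accompanies these numbers that could account for that gap.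

The compounds shown leave open whether the gap belongs to furan-2-yl alone or to the absence of a ring nitrogen, since it is the only group of the four without one. They also leave open how the number would respond at this aromatic carbon to a group without an aromatic ring, such as an amine, a carboxylic acid or a longer chain.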